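The source may report more compounds than this note shows. Statements on the series, on what has been measured and on what is new or still open speak of the compounds shown alone.

In a functional assay on the whole organism (strain Wistar) for inhibition, with Rattus norvegicus as the target, read by paw edema, with stated times of 30 min and 3 h, at a dose of 200 mg/kg by the oral route (on this read-out higher numbers stand for more inhibition at the one dose given (going by the name of the read-out) and lower numbers for less inhibition), compound 1 `O=C(O)c1cc(-n2c(-c3ccccc3)cc3c2CCCC3)ccc1O` is known only by a limit, and that limit is >= 60% (the limit of >= 60% in this assay, at which 1 of the 3 values shown sits). Two single changes to this compound have been measured, both on the ring that bears the hydroxy group. Compound 2 `O=C(O)c1cc(-n2c(-c3ccccc3)cc3c2CCCC3)ccc1Cl` gives 40%; the step is a number at least 20 percentage points lower from compound 1 to compound 2 (beyond the scatter). Compound 3 `COC(=O)c1cc(-n2c(-c3ccccc3)cc3c2CCCC3)ccc1O` gives 0%; the step is a number at least 60 percentage points lower from compound 1 to compound 3 (beyond the scatter). Compound 4 `O=C(O)c1cc(-n2c(-c3ccc([N+](=O)[O-])cc3)cc3c2CCCC3)ccc1O` differs from compound 1 in another part of the molecule: nitro in place of hydrogen on an aromatic carbon, or, cut one bond further out, phenyl to 4-nitrophenyl. Neither measured step touches that ring, so neither comparison speaks directly to this change, and there is no basis in these data for a shift in one direction or the other. The expectation is therefore of a step within the scatter, a step that the limit leaves unreadable from compound 1 to compound 4. Compound 4 is thus expected to give about 62%, within a range from 45% to 85%, with a fair chance that it too is reported only as a limit.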

Compound 4, a percentage reported as inhibition, in the whole organism at one dose (the size of the read-out at that dose, not a potency): 30%
Compound 4: middle estimate off by 32 percentage points, on the high side; measured number below the stated range.
By their numbers in this assay, from the lowest: compound 3; then compounds 4 and 2 (each within the scatter of the next). At a limit, above all of these: compound 1.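

The outer phenyl ring of the core is thus not a free place for substitution: in this assay, nitro para to a large group gives a number at least 30 percentage points lower from compound 1 to compound 4 (beyond the scatter). Until now, only changes on the ring bearing the hydroxy group had been seen to lower the number, and this result shows that the far end of the molecule matters too. The step has a minimum size but no exact size, because compound 1 is known only by a limit: the limit of >= 60% in this assay, at which 1 of the 4 values shown sits.

As far as these compounds go, what stays open is whether the loss belongs to nitro itself or would follow any group placed on this carbon. An amine or a methoxy group at the same place would help separate those two readings, and a single substituted compound cannot show a trend.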